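This account rests on a few compounds, and the source may have more. Where it says the series, first, only, none or still open, it means among the compounds named here.

Measured so far in a functional assay on the whole organism with Rattus norvegicus as the target; a higher number here means that more compound is needed for the effect, a lower number that less compound is needed:
- compound 1 `C=CCc1c(SC)nc2nc(C(=O)c3ccccc3)cn2c1C` gives 5 mg/kg
- compound 2 `CCc1c(SC)nc2nc(C(=O)c3ccccc3)cn2c1C` gives 2 mg/kg
- compound 3 `C=CCc1c(OC)nc2nc(C(=O)c3ccccc3)cn2c1C` gives 5 mg/kg

Compound 2 differs from compound 1 by methyl in place of vinyl on a saturated chain carbon bound to an aromatic carbon, and in this assay this gave a 2.5-fold lower number from compound 1 to compound 2 (0.40 log units; beyond the scatter). Compound 3 differs from compound 1 in the core: methoxy in place of methylsulfanyl on an aromatic carbon. That core change gave no change at the digits printed from compound 1 to compound 3 (within the scatter), so compound 3 and compound 1 stand level at the digits printed.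

Compound 4 `CCc1c(OC)nc2nc(C(=O)c3ccccc3)cn2c1C` is not yet measured. It differs from compound 3 by methyl in place of vinyl on a saturated chain carbon bound to an aromatic carbon. The place of this change is the same as the place of the change from compound 1 to compound 2, word for word, so it is the same change, now carried out on the core of compound 3 instead of the core of compound 1. Among the compounds with values here, since the core change itself left the number unchanged within the scatter, the step from compound 3 to compound 4 is expected to resemble the one from compound 1 to compound 2, and a step of a 2.5-fold lower number from compound 3 to compound 4 (0.40 log units; beyond the scatter) is estimated. For compound 4 in this assay the estimate is 2 mg/kg, with a likely range from 1 mg/kg to 5 mg/kg.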

Compound 4, minimum effective dose: 2 mg/kg
Beside the measured number, compound 4's estimate shows no gap at the digits printed; measured number inside the range.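

In this assay, the change from allyl to ethyl, carried onto the methoxy-bearing core, gave a 2.5-fold lower number from compound 3 to compound 4 (0.40 log units; beyond the scatter), and it matches the same change on the methylsulfanyl-bearing core: the same change on two cores in this assay, a 2.5-fold lower number (0.40 log units; beyond the scatter) from compound 1 to compound 2 and a 2.5-fold lower number (0.40 log units; beyond the scatter) from compound 3 to compound 4, 1.0-fold (0.00 log units) apart, within the scatter of two such steps

Read the other way, methoxy in place of methylsulfanyl on an aromatic carbon, now with ethyl in the chain, gave no change at the digits printed from compound 2 to compound 4 (within the scatter), and this matches the same change with allyl in the chain: the same change on two cores in this assay, no change at the digits printed (within the scatter) from compound 1 to compound 3 and no change at the digits printed (within the scatter) from compound 2 to compound 4, 1.0-fold (0.00 log units) apart, within the scatter of two such steps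

Across these four compounds the two changes therefore act independently of each other, but this rests on a single step per core and on two cores only, so it does not show that the allyl to ethyl step would hold on any other core, nor does it give a reason for the step.

As far as these compounds go, it remains open whether a longer chain such as propyl would keep the lower number seen with ethyl. Also open, from the compounds shown here alone, is how an amine on that aromatic carbon would compare with methoxy and methylsulfanyl.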